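A new group on the sulfonyl sulfur

The compounds below may be only part of what the source reports. "The series", "measured", "known", "first", "only" and "open" are said of these compounds alone.

In an ADME assay on HCT-116 cells (Homo sapiens) for cytotoxicity, read by CellTiter-Glo, with a stated time of 72 h (a lower number here means a stronger inhibitor, a higher number a weaker inhibitor), compound 1 (`CC1CCN(C2CCN(S(=O)(=O)c3cccnc3F)CC2)CC1`) gives > 10000 nM as a limit of the assay, not a number. In this assay compound 2 (`CC1CCN(C2CCN(S(=O)(=O)c3cn(C)cn3)CC2)CC1`) gives > 10000 nM and this too is only a limit. So compound 2 has no exact position, and the whole record is the limit of > 10000 nM in this assay, at which 2 of the 2 values shown sit, with no number to compare.

Compound 3 (`CC1CCN(C2CCN(S(=O)(=O)c3cc(Cl)cc(Cl)c3)CC2)CC1`) carries 3,5-dichlorophenyl in place of 1-methyl-1H-imidazol-4-yl on a sulfonyl sulfur. Within the data shown here, the only measured step (a step that the two limits leave unreadable from compound 1 to compound 2) also exchanged the group on that sulfur, but it has no readable size. Two different groups there have given the same limit, so no step beyond the usual scatter is expected in this assay and no direction can be given with confidence. The estimated step is a number no higher from compound 2 to compound 3 (the limit leaves the size open) on this reasoning. The most likely report for the new compound is another limit. For compound 3 the expected value is 10000 nM with an estimated range from 4000 nM to 20000 nM if a number is obtained.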

Compound 3, half-maximal inhibitory concentration: > 5000 nM
Compound 3 gave a limit, no number (the forecaster's own chance of this, stated with the estimate: 75%); the middle value does not contradict the limit.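

Among these compounds, compound 1, compound 2 and compound 3 all give limits of the assay, not numbers, in this assay, and no step among them can be read. The compounds shown leave open what exact value any of them has in this assay, and whether the group on the sulfonyl sulfur shifts that value at all.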